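Cyclopropyl in Place of Phenyl on the Alkynyl Nucleoside

The source may report more compounds than this note shows. Statements on the series, on what has been measured and on what is new or still open speak of the compounds shown alone.

Measured compounds: compound 1 `CCCCC#Cc1cn([C@@H]2O[C@H](CO)[C@@H](O)[C@H]2O)c(=O)[nH]c1=O`, 11600 nM; compound 2 `O=c1[nH]c(=O)n([C@@H]2O[C@H](CO)[C@@H](O)[C@H]2O)cc1C#CC(O)c1ccccc1`, 900 nM; compound 3 `O=c1[nH]c(=O)n([C@@H]2O[C@H](CO)[C@@H](O)[C@H]2O)cc1C#Cc1ccccc1`, 1200 nM.

In an ADME assay on MRC5 cells (Homo sapiens) for cytotoxicity, read by MTT assay (a lower number here means that less compound is tolerated, a higher number that more compound is tolerated), compound 3 stands second highest of the three, with compound 2 nearest at a 1.3-fold higher number from compound 2 to compound 3 (0.12 log units; within the scatter) and compound 1 furthest at a 9.7-fold lower number from compound 1 to compound 3 (0.99 log units; beyond the scatter). Compound 4 `O=c1[nH]c(=O)n([C@@H]2O[C@H](CO)[C@@H](O)[C@H]2O)cc1C#CC1CC1` differs from compound 3 by cyclopropyl in place of phenyl on a triple-bonded carbon. The step that bears on it is a 9.7-fold lower number from compound 1 to compound 3 (0.99 log units; beyond the scatter), where a six-membered aromatic ring replaced a chain; compound 4 carries a three-membered non-aromatic ring instead, so some of that step is expected to reverse. Compound 4 is therefore estimated at 4500 nM, within 1500 nM to 13000 nM, an expected step of a 3.8-fold higher number from compound 3 to compound 4 (0.57 log units; beyond the scatter).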

Compound 4, half-maximal cytotoxic concentration: 24200 nM
The estimate for compound 4 lay 5.4-fold (0.73 log units) below the measured number, outside the stated range (above it).
By their numbers in this assay, from the lowest: compounds 2 and 3 (each within the scatter of the next); then compound 1; then compound 4.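

In this assay a ring on the triple-bonded carbon does not by itself bring the lower numbers, since cyclopropyl gives a 20-fold higher number from compound 3 to compound 4 (1.30 log units; beyond the scatter) and a 27-fold higher number from compound 2 to compound 4 (1.43 log units; beyond the scatter). Cyclopropyl also stands apart from the open chain, with a 2.1-fold higher number from compound 1 to compound 4 (0.32 log units; beyond the scatter), so compound 4 has the highest number of the four. Nothing measured here accounts for this difference. Going by these compounds, it remains open whether a cyclopentyl ring on the same triple-bonded carbon would stay near compound 4 or fall toward compound 3 , and where an aminomethyl group would stand.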